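Methoxy for trifluoromethyl in the chloropyrazine urea series

The source may report more compounds than this note shows. Statements on the series, on what has been measured and on what is new or still open speak of the compounds shown alone.

Of the compounds shown here, three have numbers so far. Compound 1 `CC(C)(C)c1ccc(NC(=O)Nc2cccc(CNc3nccnc3Cl)c2)cc1` carries tert-butyl on the outer aromatic ring; in a functional assay on MGC-803 cells (Homo sapiens) for antiproliferative activity, read by MTT assay, with a stated time of 48 h (a lower number here means a stronger inhibitor, a higher number a weaker inhibitor), compound 1 gives 4820 nM. Compound 2 `O=C(Nc1cccc(CNc2nccnc2Cl)c1)Nc1ccc(F)c(Cl)c1` carries fluorine and chlorine there, and in this assay compound 2 gives 5020 nM. Compound 3 `O=C(Nc1ccc(C(F)(F)F)cc1)Nc1cccc(CNc2nccnc2Cl)c1` carries trifluoromethyl; in this assay compound 3 gives 6910 nM. Compound 3 thus has the highest of the three numbers, but its gaps to compound 2 and to compound 1 both lie within the scatter, so the three stand together. Within the data shown here, the only paired step is a 1.4-fold higher number from compound 1 to compound 3 (0.16 log units; within the scatter), also within the scatter.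

Compound 4 `COc1ccc(NC(=O)Nc2cccc(CNc3nccnc3Cl)c2)cc1` differs from compound 3 in one place: methoxy in place of trifluoromethyl on an aromatic carbon. Among the measured compounds shown here, no measured pair introduces a methoxy, so the only guide is that the exchange of tert-butyl for trifluoromethyl in the same position left the number where it was. On that basis the expected step is a 1.3-fold lower number from compound 3 to compound 4 (0.10 log units; within the scatter), that is, nothing beyond the scatter. Compound 4 is therefore estimated to give 5500 nM in this assay, with a range from 2500 nM to 12000 nM.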

Compound 4, half-maximal inhibitory concentration: 9240 nM
For compound 4 the middle estimate is 1.7-fold (0.23 log units) below the measured one; low and high end bracket the measured number.
By their numbers in this assay, from the lowest: compounds 1, 2, 3 and 4 (each within the scatter of the next).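

Working notes on the outer aromatic ring: in this assay, methoxy in place of trifluoromethyl on an aromatic carbon, para to a large group, gives a 1.3-fold higher number from compound 3 to compound 4 (0.13 log units; within the scatter). Among these compounds, this is the first measured pair that brings a hydrogen-bond acceptor to this position, and the step stays within the scatter, so an oxygen-linked group and a fluorinated carbon group cannot be told apart here. The same reading holds for the wider comparisons, with a 1.9-fold higher number from compound 1 to compound 4 (0.28 log units; within the scatter) for methoxy in place of tert-butyl and a 1.8-fold higher number from compound 2 to compound 4 (0.26 log units; within the scatter) for 4-methoxyphenyl in place of 3-chloro-4-fluorophenyl, both within the scatter, and nothing at hand offers an explanation for this flat picture.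

Across compounds 1, 2, 3 and 4, the listed steps therefore leave no group at this position standing apart from the others, and they do not show whether any substituent here matters to the number at all. Still open, from the compounds shown here alone, is whether an amine or a carboxylic acid on the same aromatic carbon, or a longer alkoxy chain in place of methoxy, would produce a step beyond the scatter.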